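Two Amide Side Chains on Two Related Chromene Cores

This account rests on a few compounds, and the source may have more. Where it says the series, first, only, none or still open, it means among the compounds named here.

Measured compounds:
- compound 1, `C=C(c1ccc(OC)cc1NC(=O)CNCC)c1ccc(OC)c2c1OC(C)(C)C=C2`: 1380 nM
- compound 2, `C=C(c1ccc2c(c1)C=CC(C)(C)O2)c1ccc(OC)cc1NC(=O)CNCC`: 2220 nM
- compound 3, `C=C(c1ccc(OC)cc1NC(=O)CN(C)C)c1ccc(OC)c2c1OC(C)(C)C=C2`: 690 nM

All three were tested in a functional assay on HCT-8 cells (Homo sapiens) for antiproliferative activity, read by MTT assay, with a stated time of 48 h; on this read-out lower numbers stand for stronger inhibition and higher numbers for weaker inhibition. Compound 1 and compound 3 share one core and differ only in the amine at the end of the amide side chain: dimethylamino in place of ethylamino on a saturated chain carbon bound to a carbonyl carbon. That change gave a 2.0-fold lower number from compound 1 to compound 3 (0.30 log units; within the scatter), a step that the usual spread of repeated measurements could account for on its own.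

Compound 2 carries the other core. In this assay compound 2 gives 2220 nM, and the difference between its core and the core of compound 1 is not broken down here. Compared with compound 3, compound 2 gives the higher number, and that gap is larger than the usual scatter; against compound 1 the two values lie within the scatter of each other.

The unmeasured compound 4, `C=C(c1ccc2c(c1)C=CC(C)(C)O2)c1ccc(OC)cc1NC(=O)CN(C)C`, carries the core of compound 2 with the side chain of compound 3: dimethylamino in place of ethylamino on a saturated chain carbon bound to a carbonyl carbon. This is the same kind of change as from compound 1 to compound 3, made at the same kind of place. Because that earlier change gave a 2.0-fold lower number from compound 1 to compound 3 (0.30 log units; within the scatter), a step of about the same size is expected here, so for compound 4 the expected step is a 2.0-fold lower number from compound 2 to compound 4 (0.30 log units; within the scatter). Compound 4 is therefore estimated at 1100 nM, most likely between 500 nM and 2500 nM, an expectation resting on a single earlier pair.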

Compound 4, half-maximal inhibitory concentration: 690 nM
Estimate against measurement, compound 4: 1.6-fold (0.20 log units) above; low and high end bracket the measured number.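

In this assay, putting dimethylamino in place of ethylamino on the core of compound 2 gave a 3.2-fold lower number from compound 2 to compound 4 (0.51 log units; beyond the scatter), and this step can be set beside the same change on the core of compound 1: the same change on two cores in this assay, a 2.0-fold lower number (0.30 log units; within the scatter) from compound 1 to compound 3 and a 3.2-fold lower number (0.51 log units; beyond the scatter) from compound 2 to compound 4, 1.6-fold (0.21 log units) apart, within the scatter of two such steps The change therefore carried over from one core to the other in the same direction, and the two steps are best read as one step of about the same size, not as a stronger effect on the core of compound 2. For the compounds shown here, still, this rests on only two pairs of compounds and two related cores, so it does not show that the change would behave the same way on any other core, and it gives no explanation of why the numbers fall.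

The compounds shown leave open how other amines at the end of the side chain would read in this assay, such as diethylamino, piperidine or morpholine, and what a longer chain carrying the amine would do. They also leave open whether the same step would appear in any other cell line.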